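Aryl Ether Exchange in a Sulfonylurea Thromboxane Series

The source may hold more compounds than are shown below. What is called first, only, known or untested is meant among the compounds shown, and "the series" means these compounds.

In a functional assay on HEK293 cells for antagonist activity at thromboxane A2 receptor (Homo sapiens), read by fluorescence and calcium flux (a lower number here means a stronger inhibitor, a higher number a weaker inhibitor), compound 2 `Cc1cccc(Oc2ccc(C#N)cc2S(=O)(=O)NC(=O)NC(C)(C)C)c1` gives 1050 nM, the lowest of the two numbers measured, whereas compound 1 `Cc1cccc(Oc2ccc(C#N)cc2S(=O)(=O)NC(=O)NC(C)C)c1` gives 2380 nM. Within the data shown here, the only measured step, a 2.3-fold lower number from compound 1 to compound 2 (0.36 log units; beyond the scatter), lies at a different place. Compound 3 `CC(C)(C)NC(=O)NS(=O)(=O)c1cc(C#N)ccc1Oc1ccc(F)cc1` differs from compound 2 by 4-fluorophenyl in place of 3-methylphenyl on an oxygen on an aromatic ring. Among the measured compounds shown here, no measured step touches this part of the molecule, so there is nothing to suggest a shift beyond the scatter. The step of a 1.0-fold higher number from compound 2 to compound 3 (0.02 log units; within the scatter) is therefore expected to be small. Compound 3 is estimated at 1100 nM, with a range from 350 nM to 3500 nM.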

Compound 3, half-maximal inhibitory concentration: 4350 nM
Estimate against measurement, compound 3: 4.0-fold (0.60 log units) below; the whole stated range lies below it.
By their numbers in this assay, from the lowest: compound 2; then compounds 1 and 3 (each within the scatter of the next).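

In this assay, the aryl ether position proves not to be neutral: 4-fluorophenyl in place of 3-methylphenyl on the oxygen gives a 4.1-fold higher number from compound 2 to compound 3 (0.62 log units; beyond the scatter), moving the series towards a weaker inhibitor at a part of the molecule the earlier pair left unchanged. No evidence is available that bears on the origin of this shift.

The exchange alters both the substituent and its ring position, and the compounds shown do not separate the two. 3-Fluorophenyl or 4-methylphenyl would be needed to tell them apart, and whether unsubstituted phenyl sits nearer compound 2 or compound 3 remains open.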